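A few compounds are considered here, and "the series" means these few. Any claim that something is new, unique, unknown or untested is made for them only; others in the source may bear on it.

Series so far, in a functional assay on A549 cells (Homo sapiens) for inhibition, read by sulforhodamine B assay, with a stated time of 48 h; a higher number here means a weaker inhibitor of growth, a lower number a stronger inhibitor of growth:
- compound 1 `COc1ccc(/C=C/C(=O)C(=Cc2cccc(F)c2)C(=O)/C=C/c2ccc(OC)c(OC)c2)cc1OC` gives 580 nM
- compound 2 `COc1ccc(/C=C/C(=O)C(=Cc2ccc(O)cc2)C(=O)/C=C/c2ccc(OC)c(OC)c2)cc1OC` gives 420 nM
- compound 3 `COc1ccc(OC)c(C=C(C(=O)/C=C/c2ccc(O)c(OC)c2)C(=O)/C=C/c2ccc(O)c(OC)c2)c1` gives 670 nM

Compound 2 lies within the scatter of both compound 1 and compound 3, so the three are not separated on these numbers. The step to follow leads to compound 4 `COc1ccc(C=C(C(=O)/C=C/c2ccc(OC)c(OC)c2)C(=O)/C=C/c2ccc(OC)c(OC)c2)c(OC)c1`, which is not yet measured: 2,4-dimethoxyphenyl in place of 4-hydroxyphenyl on a double-bonded chain carbon bound to a double-bonded chain carbon.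

Among the compounds with values here, only one measured step bears directly on this place: a 1.4-fold lower number from compound 1 to compound 2 (0.14 log units; within the scatter). Within the data shown here, compound 3 differs from compound 2 in more than one place and gives no single step, although compound 3 at 670 nM stays close to the others. This is thin evidence, resting on one small step, and it gives no direction. No shift beyond the scatter is therefore expected in this assay. The estimated step is a 1.2-fold higher number from compound 2 to compound 4 (0.08 log units; within the scatter). For compound 4 the expected value is 500 nM, with an estimated range of 200 nM to 1300 nM.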

Compound 4, concentration for 50% growth inhibition: 650 nM
Estimate against measurement, compound 4: 1.3-fold (0.11 log units) below; low and high end bracket the measured number.
By their numbers in this assay, from the lowest: compounds 2, 1, 4 and 3 (each within the scatter of the next).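

In this assay, the place on a double-bonded chain carbon bound to a double-bonded chain carbon now has three groups in compounds that differ only there, and neither new step leaves the scatter: a 1.5-fold higher number from compound 2 to compound 4 (0.19 log units; within the scatter) and a 1.1-fold higher number from compound 1 to compound 4 (0.05 log units; within the scatter). Going from 4-hydroxyphenyl to 2,4-dimethoxyphenyl takes this place from 1 hydrogen-bond donor to 0, yet these numbers do not separate the compounds, so 3-fluorophenyl, 4-hydroxyphenyl and 2,4-dimethoxyphenyl are interchangeable here within this assay's resolution. No measurement shown gives a reason for this flat result.

All three groups at this place are substituted phenyl rings, so these numbers cannot say whether the flat response extends beyond them. Going by these compounds, what a carboxylic acid or an amine on that ring would do, or a longer chain in its stead, remains open.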